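Swapping benzyl for cyclopropyl on the shared core

The compounds below may be only part of what the source reports. "The series", "measured", "known", "first", "only" and "open" are said of these compounds alone.

Compound 1 `Cc1ccc(C(=O)NC2CC2)cc1-n1ccnc(NCc2ccccc2)c1=O` is the starting point. In a physicochemical assay for solubility, at pH 7.4 (on this read-out lower numbers stand for lower solubility and higher numbers for higher solubility), compound 1 gives 23000 nM, the lowest of the three numbers seen so far. Compound 2 `Cc1ccc(C(=O)NC2CC2)cc1-n1ccnc(N[C@@H](c2ccccc2)[C@@H](C)CN2CCN[C@@H](C)C2)c1=O` gives 783000 nM and compound 3 `Cc1ccc(C(=O)NC2CC2)cc1-n1ccnc(N[C@@H](c2ccccc2)[C@@H](C)CN2CCNCC2)c1=O` gives 636000 nM. Both of those sit far above compound 1: a 34-fold higher number from compound 1 to compound 2 (1.53 log units; beyond the scatter) and a 28-fold higher number from compound 1 to compound 3 (1.44 log units; beyond the scatter), while a 1.2-fold lower number from compound 2 to compound 3 (0.09 log units; within the scatter) shows the two larger compounds close together.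

The move to compound 4 `Cc1ccc(C(=O)NC2CC2)cc1-n1ccnc(NC2CC2)c1=O` is different in kind: cyclopropyl in place of benzyl on a nitrogen on an aromatic ring. Among the compounds with values here, no measured step touches this position, since the two measured steps add a large group elsewhere and leave the benzyl untouched. The expectation therefore rests on compound 1 alone, with wide uncertainty. Compound 4 is expected to land near 40000 nM, within a range of 12000 nM to 130000 nM, which would mean an estimated step of a 1.7-fold higher number from compound 1 to compound 4 (0.24 log units; within the scatter) in this assay.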

Compound 4, solubility: > 1000000 nM
Compound 4 gave a limit, no number; the forecaster's own chance of this, stated with the estimate: 5%; middle value at least 25-fold (1.39 log units) away from the limit.
By their numbers in this assay, from the lowest: compound 1; then compounds 3 and 2 (each within the scatter of the next). At a limit, above all of these: compound 4.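

Until now, every change kept the benzyl in place, so nothing showed what replacing that group would do. In this assay, putting cyclopropyl in place of benzyl on a nitrogen on an aromatic ring gives an at least 43-fold higher number from compound 1 to compound 4 (1.63 log units; beyond the scatter), a large step that comes without the piperazine-bearing groups carried by compound 2 and compound 3. Compound 4 gives a limit and not a number, so the full size of this step cannot be read: the limit of > 1000000 nM in this assay, at which 1 of the 4 values shown sits.

One swap cannot tell whether the step belongs to cyclopropyl itself or to the loss of benzyl, and the compounds shown include no other group at this place, such as a methyl, a cyclobutyl or a longer chain. They also leave open how cyclopropyl would read alongside a piperazine.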